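The source may report more compounds than this note shows. Statements on the series, on what has been measured and on what is new or still open speak of the compounds shown alone.

Of the compounds shown here, three sharing one core have been measured in a physicochemical assay for solubility, read by spectrophotometry, in phosphate buffer, with a stated time of 18 h, at pH 7.4; on this read-out lower numbers stand for lower solubility and higher numbers for higher solubility. Compound 1 (`CCc1ccc(-c2nc3c(c(C)nn3-c3ccccc3)c(-c3ccccc3C#N)c2C#N)cc1`), the cyano member, gives (2400 nM), compound 2 (`CCc1ccc(-c2nc3c(c(C)nn3-c3ccccc3)c(-c3ccccc3I)c2C#N)cc1`), the iodo member, gives (8500 nM), and compound 3 (`CCc1ccc(-c2nc3c(c(C)nn3-c3ccccc3)c(-c3ccccc3C)c2C#N)cc1`), the methyl member, gives (6000 nM). Compound 3 therefore stands level with compound 2 within the scatter and clear of compound 1 on the high side. Compound 4 (`CCc1ccc(-c2nc3c(c(C)nn3-c3ccccc3)c(-c3ccccc3OC(F)(F)F)c2C#N)cc1`) carries trifluoromethoxy in place of methyl on an aromatic carbon, ortho to a large group (trifluoromethoxy in place of methyl on an aromatic carbon). Two measured steps leave cyano, and both were modest (a 3.5-fold higher number from compound 1 to compound 2 (0.55 log units; beyond the scatter)) and (a 2.5-fold higher number from compound 1 to compound 3 (0.40 log units; beyond the scatter)). The step that bears most closely on the new change involves no cyano, and it stayed within the scatter (a 1.4-fold lower number from compound 2 to compound 3 (0.15 log units; within the scatter)). For the measured compounds named here, no measured compound carries trifluoromethoxy, so the direction is uncertain, and no step beyond the scatter is expected in this assay here. The estimated step is (a 1.2-fold lower number from compound 3 to compound 4 (0.08 log units; within the scatter)) and it is expected to be small. For compound 4 the estimated value is (5000 nM), with an expected range from (2000 nM) to (11000 nM) in this read-out.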

Compound 4, solubility: 9900 nM
Estimate against measurement, compound 4: 2.0-fold (0.30 log units) below; the range from low to high includes it.
By their numbers in this assay, from the lowest: compound 1; then compounds 3, 2 and 4 (each within the scatter of the next).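

In (this assay), trifluoromethoxy on this aromatic carbon, ortho to a large group, falls in the same band as methyl and iodo, with (a 1.7-fold higher number from compound 3 to compound 4 (0.22 log units; within the scatter)) and (a 1.2-fold higher number from compound 2 to compound 4 (0.07 log units; within the scatter)). Replacing the single carbon of methyl with a group of carbon, oxygen and fluorine therefore produced no step beyond the scatter, a wider change at this position than the earlier methyl and iodo pair had tested. Trifluoromethoxy also stands clear of cyano, with (a 4.1-fold higher number from compound 1 to compound 4 (0.62 log units; beyond the scatter)), so compound 1 remains the only one of the four set apart from the others.

Nothing available here explains why compound 1 stands apart. As far as these compounds go, it remains open whether an amine, a carboxylic acid or a hydroxyl group at this position would stay with methyl, iodo and trifluoromethoxy or fall nearer cyano.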